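Amide aryl variation and paw edema inhibition

A few compounds are considered here, and "the series" means these few. Any claim that something is new, unique, unknown or untested is made for them only; others in the source may bear on it.

The series shares one core. Compound 1 `CNC(=O)c1nc(-c2cc(OC)c(OC)c(OC)c2)n(-c2ccc(OC)cc2)n1` carries a methyl on the amide-type nitrogen, compound 2 `COc1ccc(-n2nc(C(=O)Nc3ccccc3OC)nc2-c2cc(OC)c(OC)c(OC)c2)cc1` a 2-methoxyphenyl and compound 3 `COc1ccc(-n2nc(C(=O)Nc3ccccc3C)nc2-c2cc(OC)c(OC)c(OC)c2)cc1` a 2-methylphenyl. In a functional assay on the whole organism for inhibition, with Rattus norvegicus as the target, read by paw edema, with stated times of 30 min and 3 h, at a dose of 0.28 mmol/kg by the oral route (on this read-out lower numbers stand for less inhibition and higher numbers for more inhibition at the one dose given (going by the name of the read-out)), compound 1 gives 74%, compound 2 gives 30% and compound 3 gives 50%. Compound 3 stands second highest of the three; the steps that place it are a number 20 percentage points higher from compound 2 to compound 3 (beyond the scatter) and a number 24 percentage points lower from compound 1 to compound 3 (beyond the scatter). The remaining step, a number 44 percentage points lower from compound 1 to compound 2 (beyond the scatter), is the larger of the two losses seen on going from methyl to an aryl group on this nitrogen.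

Compound 4 `COc1ccc(-n2nc(C(=O)Nc3cccc(F)c3)nc2-c2cc(OC)c(OC)c(OC)c2)cc1` differs from compound 3 in one place: 3-fluorophenyl in place of 2-methylphenyl on an amide-type nitrogen. Going by the values given here, no measured step exchanges one aryl substituent for another in this way; the nearest guide is a number 20 percentage points higher from compound 2 to compound 3 (beyond the scatter), which shows that a single change on this ring moves the read-out by a modest amount, while both aryl compounds stay below compound 1. The step of a number 5 percentage points lower from compound 3 to compound 4 (within the scatter) is therefore estimated as small, of uncertain direction, and the new compound is expected to remain within the span set by the two aryl compounds. Compound 4 is expected to give about 45% in this assay, within a range from 25% to 65%.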

Compound 4, a percentage reported as inhibition, in the whole organism at one dose (the size of the read-out at that dose, not a potency): 72%
Estimate against measurement, compound 4: 27 percentage points below, outside the stated range (above it).
By their numbers in this assay, from the lowest: compound 2; then compound 3; then compounds 4 and 1 (each within the scatter of the next).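

Working notes on the amide-type nitrogen: in this assay, an aryl group here does not by itself bring a loss, since the step to 3-fluorophenyl is a number 2 percentage points lower from compound 1 to compound 4 (within the scatter), unlike the clear falls seen with 2-methylphenyl and 2-methoxyphenyl. The identity of the aryl group therefore decides the outcome, with a number 22 percentage points higher from compound 3 to compound 4 (beyond the scatter) and a number 42 percentage points higher from compound 2 to compound 4 (beyond the scatter); 2-methylphenyl and 3-fluorophenyl both have 7 heavy atoms, so this heavy-atom count does not separate them. No available measurement bears on why the read-out moves with this exchange.

The name of the substituent and the number of its ring position both differ between 2-methylphenyl and 3-fluorophenyl, so the compounds shown cannot assign the gain to either one alone; 2-fluorophenyl and 3-methylphenyl would separate the two. Also open, on these data alone, is how unsubstituted phenyl, 4-fluorophenyl or an ethyl group on this nitrogen would read, and whether a longer chain would stand with the methyl of compound 1.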